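This account rests on a few compounds, and the source may have more. Where it says the series, first, only, none or still open, it means among the compounds named here.

Series notes, core with a cyclopentylamino group and a methyl on the five-membered ring.

Compound 1 `COc1ccc(-c2nc3c(NC4CCCC4)ncnc3n2C)cc1` carries a 4-methoxyphenyl on the aromatic carbon of that ring. In a functional assay on CHO cells for antagonist activity at adenosine receptor A2b (Homo sapiens), read by 33P incorporation, with a stated time of 20 min (a lower number here means a stronger inhibitor, a higher number a weaker inhibitor), compound 1 gives > 30000 nM, which is a limit of the assay and not a number. Compound 2 `Cn1c(-c2cccnc2)nc2c(NC3CCCC3)ncnc21` has pyridin-3-yl in place of 4-methoxyphenyl on an aromatic carbon. In this assay compound 2 gives > 30000 nM, again a limit of the assay and not a number. The step that the two limits leave unreadable from compound 1 to compound 2 is therefore unreadable; both values sit at the limit of > 30000 nM in this assay, at which 2 of the 2 values shown sit, so compound 2 stands at the limit with no number of its own.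

Compound 3 `Cn1c(-c2ccccc2)nc2c(NC3CCCC3)ncnc21` differs from compound 2 by phenyl in place of pyridin-3-yl on an aromatic carbon. For the measured compounds named here, the only measured step bearing on this change is the unreadable one from compound 1 to compound 2, which gives no size and no direction. With both neighbours at the limit, the expected step that the limit leaves unreadable from compound 2 to compound 3 is nothing readable beyond the scatter, and compound 3 is most likely to return a limit as well. For compound 3 the estimate in this assay is 50000 nM, with a range from 10000 nM to 300000 nM.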

Compound 3, inhibition constant: 8510 nM
The estimate for compound 3 lay 5.9-fold (0.77 log units) above the measured number; measured number below the stated range.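

The aromatic carbon of the five-membered ring, between two ring nitrogen atoms, is a place where the group can bring out a measurable result: in this assay compound 3, with a plain phenyl, gives 8510 nM, the only real number among the compounds shown. Both changes that lead to it count, with phenyl in place of pyridin-3-yl giving an at least 3.5-fold lower number from compound 2 to compound 3 (0.54 log units; beyond the scatter), and hydrogen in place of methoxy on the phenyl giving an at least 3.5-fold lower number from compound 1 to compound 3 (0.54 log units; beyond the scatter). Each size is only a lower bound, because compound 1 and compound 2 both stand at a limit of the assay and not at a number: the limit of > 30000 nM in this assay, at which 2 of the 3 values shown sit.

The step from compound 1 to compound 2 stays unreadable, so the methoxy and the pyridine nitrogen cannot be ranked against each other, and with a single number the series gives no measure of how much room this position allows. Also open, on these data alone, is how the result would move with a phenyl carrying a fluorine, an amine or a carboxylic acid, or with a saturated ring such as cyclohexyl at this place.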